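This account rests on a few compounds, and the source may have more. Where it says the series, first, only, none or still open, it means among the compounds named here.

Series notes. Of the compounds shown here, three have been measured in an in vitro ADME assay on microsomes from liver (Homo sapiens) for metabolic stability, tested at 5 uM; a lower number here means that the compound disappears faster, a higher number that the compound lasts longer. Compound 1, `CC(C)CCn1nc(-c2cccs2)c(O)c(C2=NS(=O)(=O)c3cc(S(C)(=O)=O)ccc3N2)c1=O`, gives 0.0933 h. Compound 2, `CS(=O)(=O)Nc1ccc2c(c1)S(=O)(=O)N=C(c1c(O)c(-c3ccsc3)nn(CCC3CC3)c1=O)N2`, gives 0.517 h. Compound 3, `CC(C)CCn1nc(C2CCCCC2)c(O)c(C2=NS(=O)(=O)c3cc(NS(C)(=O)=O)ccc3N2)c1=O`, gives 0.117 h. Within these three numbers compound 3 stands second highest: its nearest neighbour is compound 1, whose value is within the scatter of compound 3, so no order between the two is claimed; the furthest is compound 2, whose value lies beyond the scatter on the higher side. Among the compounds with values here, no pair among the three differs in a single place, so no measured step isolates any one change.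

Compound 4, `CC(C)CCn1nc(CCC(F)(F)F)c(O)c(C2=NS(=O)(=O)c3cc(NS(C)(=O)=O)ccc3N2)c1=O`, is not yet measured in this assay . Compared with compound 3 it carries 3,3,3-trifluoropropyl in place of cyclohexyl on an aromatic carbon. Within the data shown here, nothing among the measured compounds speaks directly to this exchange, and the two nearer values, those of compound 3 and compound 1, sit close to one another. The step from compound 3 to compound 4 is therefore expected to stay within the scatter, with at most a slight lean upward, as a 1.3-fold higher number from compound 3 to compound 4 (0.11 log units; within the scatter). For compound 4 in this assay the half-life is estimated at 0.15 h, with a range from 0.07 h to 0.35 h.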

Compound 4, half-life: 0.517 h
Compound 4: the middle estimate sits 3.4-fold (0.54 log units) below what was measured; the whole stated range lies below it.
By their numbers in this assay, from the lowest: compounds 1 and 3 (each within the scatter of the next); then compounds 2 and 4 (each within the scatter of the next).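

In this assay, within the data shown here, the aromatic carbon next to the ring nitrogen and ortho to a hydroxy group is the first place where a single exchange can be read: 3,3,3-trifluoropropyl in place of cyclohexyl gives a 4.4-fold higher number from compound 3 to compound 4 (0.65 log units; beyond the scatter). The half-life is therefore sensitive to the group at this position, even with the rest of the structure held constant. The exchange keeps the heavy-atom count and adds no hydrogen-bond donor or acceptor, but it removes the carbon-only ring and brings in fluorine; no measurement shown explains the step.

The compounds shown do not separate the loss of the ring from the arrival of fluorine: a plain propyl chain and a cyclohexyl ring carrying fluorine at this position would be needed to tell the two apart. From the compounds shown here alone, it also remains open whether the step holds with a group other than isopentyl on the ring nitrogen, since compound 1 and compound 2 each differ from compound 4 in more than one place.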